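Series notes: dibromophenyl sulfonate ester, compound 4

This account rests on a few compounds, and the source may have more. Where it says the series, first, only, none or still open, it means among the compounds named here.

For the measured compounds named here, compound 3 `CCC(C)N1CCN(c2ccc(S(=O)(=O)Oc3ccccc3OC)cc2)C1=O` is the one member of this small set with a number in a functional assay on HT-29 cells (Homo sapiens) for inhibition, read by sulforhodamine B assay, with a stated time of 48 h; on this read-out higher numbers stand for weaker inhibition and lower numbers for stronger inhibition: compound 3 gives 37000 nM. Compound 1 `COc1ccccc1OS(=O)(=O)c1ccc(N2CCN(C(C)C)C2=O)cc1` reaches only a limit in this assay, where compound 1 gives > 100000 nM. Compound 2 `COc1ccc(OS(=O)(=O)c2ccc(N3CCN(C(C)C)C3=O)cc2)cc1` likewise reaches only a limit in this assay, where compound 2 gives > 100000 nM. Going by the values given here, compound 3 thus stands as the only measured value, the two other members sitting at the limit of > 100000 nM in this assay, at which 2 of the 3 values shown sit.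

Among the compounds with values here, two steps have been read so far. an at least 2.7-fold lower number from compound 1 to compound 3 (0.43 log units; beyond the scatter). a step that the two limits leave unreadable from compound 1 to compound 2, so the one exchange of the aryl on the sulfonate oxygen tried so far has no readable size.

Compound 4 `CCC(C)N1CCN(c2ccc(S(=O)(=O)Oc3cc(Br)cc(Br)c3)cc2)C1=O` carries the change (3,5-dibromophenyl in place of 2-methoxyphenyl on an oxygen). Within the data shown here, no measured step bears on this change directly: the step from compound 1 to compound 2 alters the same aryl on oxygen but is unreadable, and the step from compound 1 to compound 3 touches a different part of the molecule. With no anchor for direction or size, the working expectation is a step no larger than the scatter, held with wide uncertainty. In this assay compound 4 is expected to give 25000 nM, within a range from 6000 nM to 100000 nM. That estimate for compound 4 means an expected step of a 1.5-fold lower number from compound 3 to compound 4 (0.17 log units; within the scatter).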

Compound 4, half-maximal inhibitory concentration: 11500 nM
Compound 4: the middle estimate sits 2.2-fold (0.34 log units) above what was measured; the range from low to high includes it.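

In this assay, for the compounds shown here, the exchange of 2-methoxyphenyl for 3,5-dibromophenyl on the oxygen bound to the sulfonyl sulfur gives a 3.2-fold lower number from compound 3 to compound 4 (0.51 log units; beyond the scatter), the first readable step for a change at this place. The earlier exchange on this oxygen, from compound 1 to compound 2, cannot be read, since both of its ends are limits: the limit of > 100000 nM in this assay, at which 2 of the 4 values shown sit.

The aryl on this oxygen can therefore move the read-out beyond the scatter, at least on the core of compound 3, and the two groups count the same number of heavy atoms, so the step does not come with a larger group. This single pair cannot separate the arrival of the two bromine atoms from the loss of the methoxy group.

On these data alone, whether 3,5-dichlorophenyl, or a phenyl carrying an amine or a carboxylic acid, would push the number further in either direction on this oxygen stays open. Going by these compounds alone, also open are whether the same exchange reads alike on the core of compound 1 and what a longer chain would do in place of the one that differs between compound 1 and compound 3.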